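A few compounds are considered here, and "the series" means these few. Any claim that something is new, unique, unknown or untested is made for them only; others in the source may bear on it.

Measured so far:
compound 1 `Nc1cc(-c2ccccc2)nn1C(=O)c1csc(-c2ccccc2)n1` — 60.1%
compound 2 `Nc1nnc(-c2csc(-c3ccccc3)n2)o1` — 20.3%
compound 3 `S=c1[nH]nc(-c2csc(-c3ccccc3)n2)o1` — 58.1%

In a functional assay on the whole organism (Abdomen, strain Albino) for inhibition, with Mus musculus as the target, with stated times of 50 min and 10 min, at a dose of 25 mg/kg by the oral route (a lower number here means less inhibition, a higher number more inhibition at the dose given (going by the name of the read-out)), compound 1 gives 60.1%, compound 2 gives 20.3% and compound 3 gives 58.1%. On these three numbers compound 3 sits close to compound 1, the gap lying within the usual scatter, and well above compound 2, that gap lying beyond it. Going by the values given here, no pair of measured compounds differs in one place only, so nothing among them shows how a single structural change moves the read-out of this assay; the three numbers stand on their own.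

Compound 4 `S=c1oc(-c2csc(-c3ccccc3)n2)nn1CN1CCCCC1` is the next compound to be run in this assay. It differs from compound 3 by (piperidin-1-yl)methyl in place of hydrogen on an aromatic nitrogen. Without a comparable step among the measured compounds, the expectation for this assay can only be cautious: a step of modest size, downward or none beyond the scatter, is expected, so that the estimate for compound 4 corresponds to a step of a number 8.1 percentage points lower from compound 3 to compound 4 (within the scatter). Compound 4 is therefore expected to give about 50% in this assay, with the estimate ranging from 30% to 70%.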

Compound 4, a percentage reported as inhibition, in the whole organism at one dose (the size of the read-out at that dose, not a potency): 58.7%
Compound 4: the middle estimate sits 8.7 percentage points below what was measured, and the stated range covers the measured number.
By their numbers in this assay, from the lowest: compound 2; then compounds 3, 4 and 1 (each within the scatter of the next).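

In this assay the series now has its first change in one place: (piperidin-1-yl)methyl in place of hydrogen on the aromatic nitrogen gives a number 0.6 percentage points higher from compound 3 to compound 4 (within the scatter). At this position, therefore, the hydrogen can be replaced by this much larger group, with its six-membered non-aromatic ring, without a shift beyond the scatter in the inhibition read at this single oral dose, so the read-out does not depend on that hydrogen being present, at least with this replacement. No measurement bears on why the read-out stays level across this change.

As far as these compounds go, with only one replacement at this aromatic nitrogen, it remains open whether the position is equally open to a plain methyl, a morpholin-4-ylmethyl, a dimethylaminomethyl or a longer chain ending in a carboxylic acid, so the level step cannot yet be read as a rule for the position. From the compounds shown here alone, because the read-out is the size of the effect at a single dose and not a potency, a difference between the two compounds at other doses or in the time course also remains open.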